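One Drawn Stereocentre in a Closely Matched Set

The source may report more compounds than this note shows. Statements on the series, on what has been measured and on what is new or still open speak of the compounds shown alone.

In a functional assay for inhibition, with Homo sapiens as the target (a lower number here means a stronger inhibitor, a higher number a weaker inhibitor), compound 1 (`CC(C)(C)Sc1c(CC(C)(C)C(=O)O)n(Cc2ccc(Cl)cc2)c2ccc(OCc3ccc4cc(F)c(F)cc4n3)cc12`) gives 7 nM while compound 2 (`CC(C)(C)Sc1c(CC(C)(C)C(=O)O)n(Cc2ccc(Cl)cc2)c2ccc(OCc3ccc4cccnc4n3)cc12`) gives 6 nM and compound 3 (`CC(COc1ccc2c(c1)c(SC(C)(C)C)c(CC(C)(C)C(=O)O)n2Cc1ccc(Cl)cc1)c1ccccn1`) gives 4 nM so compound 3 stands within the scatter of both other compounds.

Compound 4 (`C[C@@H](COc1ccc2c(c1)c(SC(C)(C)C)c(CC(C)(C)C(=O)O)n2Cc1ccc(Cl)cc1)c1ccccn1`) keeps the atoms and bonds of compound 3. The change is the two compounds have the same atoms and bonds; at least one stereo element is drawn with a configuration in one of them and without one in the other: 1 of 1 stereo elements differ; a stereocentre at a saturated chain carbon is drawn without a configuration in compound 3 and R in compound 4 and it concerns only a stereocentre at a saturated chain carbon, drawn without a configuration in compound 3 and R in compound 4.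

Among the measured compounds shown here, no measured pair compares configurations, so the available steps bear on this change only indirectly. All three exchange the group on a saturated chain carbon bound to an oxygen on an aromatic ring. They are a 1.2-fold lower number from compound 1 to compound 2 (0.07 log units; within the scatter) then a 1.8-fold lower number from compound 1 to compound 3 (0.24 log units; within the scatter) and finally a 1.5-fold lower number from compound 2 to compound 3 (0.18 log units; within the scatter) and none leaves the scatter. With the number this flat across larger exchanges of atoms, a change of drawn configuration alone is expected to produce no step beyond the scatter, although the data cannot exclude one.

In this assay the estimated step is a 1.3-fold lower number from compound 3 to compound 4 (0.12 log units; within the scatter) and it is expected to remain within the scatter. Compound 4 is estimated at 3 nM with an expected range of 1.3 nM to 9 nM in this measurement.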

Compound 4, half-maximal inhibitory concentration: 2 nM
Compound 4: middle estimate off by 1.5-fold (0.18 log units), on the high side, within the range that was stated.
By their numbers in this assay, from the lowest: compounds 4, 3, 2 and 1 (each within the scatter of the next, the first and the last beyond it).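

Drawing the R configuration at the saturated chain carbon gives a 2.0-fold lower number from compound 3 to compound 4 (0.30 log units; within the scatter) in this assay, so this first look at the stereocentre yields a step that stays inside the scatter. The two structures differ at this place in nothing but the drawing: the fact that one of compounds 3 and 4 is drawn with a defined configuration and the other without, at the place where they differ Across the exchanges of the group on the saturated chain carbon, however, the picture changes, since a 3.0-fold lower number from compound 2 to compound 4 (0.48 log units; beyond the scatter) and a 3.5-fold lower number from compound 1 to compound 4 (0.54 log units; beyond the scatter) both lie beyond the scatter, if only modestly, whereas compound 3 stood within the scatter of compound 1 and compound 2, so a separation in this short series appears only once the configuration is defined.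

The compounds shown leave open what the S configuration at this stereocentre gives, and whether compound 3 is a mixture of both configurations, so the role of configuration here cannot yet be judged from a direct comparison. They also leave open whether the same picture holds with an ethyl group in place of the methyl group on the stereocentre, or with a primary amide in place of the carboxylic acid.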